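Adding a methoxy to the core of compound 1

A few compounds are considered here, and "the series" means these few. Any claim that something is new, unique, unknown or untested is made for them only; others in the source may bear on it.

Among the measured compounds shown here, in a physicochemical assay for solubility, in phosphate buffer, with a stated time of 18 h, at pH 7.4 (a higher number here means a more soluble compound, a lower number a less soluble compound), compound 1 (`Nc1nc(-c2ccccn2)nn1-c1ncnc2ccccc12`) gives 9000 nM while compound 2 (`COc1ccc(-c2nc(N)n(-c3ncnc4ccccc34)n2)cc1`) gives 5000 nM as the only other measured number. These two sit within the usual scatter of each other, so compound 1 holds no clear rank. Compound 3 (`COc1ccc2ncnc(-n3nc(-c4ccccn4)nc3N)c2c1`) is compound 1 with one change (methoxy in place of hydrogen on an aromatic carbon) on the shared core: methoxy in place of hydrogen on an aromatic carbon. For the measured compounds named here, the one measured step (a 1.8-fold lower number from compound 1 to compound 2 (0.26 log units; within the scatter)) also brings in a methoxy, though as 4-methoxyphenyl in place of pyridin-2-yl, so it is only a loose guide. It stays within the scatter, and no step beyond the scatter is expected here in this assay either. The estimated step is small (a 1.5-fold lower number from compound 1 to compound 3 (0.18 log units; within the scatter)). The value expected for compound 3 is 6000 nM (range 2000 nM to 15000 nM).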

Compound 3, solubility: 7000 nM
Compound 3: middle estimate off by 1.2-fold (0.07 log units), on the low side; measured number inside the range.
By their numbers in this assay, from the lowest: compounds 2, 3 and 1 (each within the scatter of the next).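

In this assay putting methoxy in place of hydrogen on this aromatic carbon of the shared core gives a 1.3-fold lower number from compound 1 to compound 3 (0.11 log units; within the scatter) and so leaves compound 3 within the scatter of compound 1. Among the compounds shown here, the earlier step swapped one whole ring group for another at a different place, so this is the first direct reading of a change on this six-membered ring of carbon only. No measurement shown here explains the result.

A single group at one place cannot show whether this position accepts other groups in general. On these data alone, an amine, a carboxylic acid or a longer chain on the same carbon might stay within the scatter or move clearly away from compound 1, and methoxy on the other carbons of this ring also remains open.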